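The compounds below may be only part of what the source reports. "The series", "measured", "known", "first", "only" and "open" are said of these compounds alone.

Measured compounds in this series:

compound 1 `CCC1(CCCCN2CCN(c3ccc(Cl)cc3)CC2)C(=O)Nc2cc(F)ccc21` — > 20 mg/kg
compound 2 `CCC1(CCCCN2CCN(c3ccccc3OC)CC2)C(=O)Nc2ccccc21` — 10 mg/kg
compound 3 `CCC1(CCCCN2CCN(c3ccccc3OC)CC2)C(=O)N(Cc2ccccc2)c2ccccc21` — > 20 mg/kg

In a functional assay on the whole organism (strain Wistar) with Rattus norvegicus as the target, with a stated time of 5 min (on this read-out higher numbers stand for an effect only at larger amounts of compound and lower numbers for an effect already at smaller amounts), compound 2 gives 10 mg/kg. For compound 1 the entry > 20 mg/kg is a limit of the assay, not a number. For compound 3 the entry > 20 mg/kg is likewise a limit. Among the compounds with values here, compound 2 therefore stands as the only compound with a measured number; the other two sit at the limit of > 20 mg/kg in this assay, at which 2 of the 3 values shown sit.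

Within the data shown here, the single measured step, an at least 2.0-fold higher number from compound 2 to compound 3 (0.30 log units; that floor lies within the scatter), concerns the amide-type nitrogen in the ring and reaches only the limit, so its size is known only as a floor.

Compound 4 `CCC1(CCCCN2CCN(c3ccccc3Cl)CC2)C(=O)Nc2ccccc21` differs from compound 2 by chloro in place of methoxy on an aromatic carbon, that is 2-methoxyphenyl to 2-chlorophenyl. Among the measured compounds shown here, no measured step touches this position: the one step measured lies at the ring nitrogen, and compound 1, which carries chloro, also differs from compound 2 elsewhere, so the pair of compound 1 and compound 2 shows only a limit against a number. With nothing to weigh, no change beyond the scatter is assumed.

Compound 4 is thus expected to give about 10 mg/kg in this assay, within 5 mg/kg to 20 mg/kg. For compound 4 the step expected from this is no change at the digits printed from compound 2 to compound 4 (within the scatter).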

Compound 4, minimum effective dose: > 20 mg/kg
Compound 4 was reported as a limit; the forecaster's own chance of this, stated with the estimate: 35%; middle value at least 2.0-fold (0.30 log units) from the limit.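

The change from 2-methoxyphenyl to 2-chlorophenyl, on an aromatic carbon ortho to a large group, gives in this assay an at least 2.0-fold higher number from compound 2 to compound 4 (0.30 log units; that floor lies within the scatter). Within the data shown here, this is the first one-place comparison at this position, and it ends at a limit of the assay, so only a floor is known and that floor does not separate the change from the scatter. Compound 2, with methoxy, remains the only compound with a measured number, and chloro at this position adds one more entry at the limit: the limit of > 20 mg/kg in this assay, at which 3 of the 4 values shown sit.

On these data alone, how far compound 4 lies past the limit stays open, so the real size of this change cannot be read. Also open, as far as these compounds go, is whether another group on this aromatic carbon, such as ethoxy, hydroxy, methyl or dimethylamino, would give a measured number, and whether the methoxy oxygen or the mere presence of a group there matters, which hydrogen in place of methoxy would begin to address.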